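Furan-2-yl to 2-hydroxypentyl on a carbonyl carbon

The source may hold more compounds than are shown below. What is called first, only, known or untested is meant among the compounds shown, and "the series" means these compounds.

In a functional assay on HeLa cells (Homo sapiens) for cytotoxicity, read by MTT assay (a lower number here means a stronger inhibitor, a higher number a weaker inhibitor), compound 1 `CC(C)=CC[C@@H](OC(=O)CCO)C1=CC(=O)c2c(O)ccc(O)c2C1=O` gives 67600 nM and compound 2 `CC(C)=CC[C@@H](OC(=O)c1ccco1)C1=CC(=O)c2c(O)ccc(O)c2C1=O` gives 80300 nM. These two values lie within the scatter of each other, so compound 2 has no separate rank. Compound 3 `CCCC(O)CC(=O)O[C@H](CC=C(C)C)C1=CC(=O)c2c(O)ccc(O)c2C1=O` differs from compound 2 as follows: 2-hydroxypentyl in place of furan-2-yl on a carbonyl carbon. Among the compounds with values here, the one measured step that bears on this is a 1.2-fold higher number from compound 1 to compound 2 (0.07 log units; within the scatter), furan-2-yl in place of 2-hydroxyethyl on a carbonyl carbon. Within the data shown here, with only that small step to go on, no shift beyond the scatter is expected in this assay. The estimated step is a 1.2-fold lower number from compound 2 to compound 3 (0.09 log units; within the scatter). Compound 3 is expected at 65000 nM, with an estimated range of 30000 nM to 120000 nM.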

Compound 3, half-maximal inhibitory concentration: 59300 nM
The estimate for compound 3 lay 1.1-fold (0.04 log units) above the measured number; low and high end bracket the measured number.
By their numbers in this assay, from the lowest: compounds 3, 1 and 2 (each within the scatter of the next).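

In this assay, 2-hydroxypentyl in place of furan-2-yl on this carbonyl carbon gives a 1.4-fold lower number from compound 2 to compound 3 (0.13 log units; within the scatter) and propyl in place of hydrogen on the saturated chain carbon gives a 1.1-fold lower number from compound 1 to compound 3 (0.06 log units; within the scatter) in the hydroxy chain series. Neither loss of the furan-2-yl ring nor the added propyl separates these compounds at this position. No evidence on any cause accompanies these numbers.

From the compounds shown here alone, whether an amine, a carboxylic acid or a longer chain here would move the number beyond the scatter remains open.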